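One more methoxy on the core of compound 2

The source may hold more compounds than are shown below. What is called first, only, known or untested is meant among the compounds shown, and "the series" means these compounds.

Compound 1 `COc1cc2nc(-c3cccc(F)c3)nc(O)c2cc1OC` stands at > 20 ug/mL in a functional assay on A549 cells (Homo sapiens) (on this read-out higher numbers stand for an effect only at larger amounts of compound and lower numbers for an effect already at smaller amounts), as a limit of the assay and not a number. Compound 2 `COc1cccc(-c2nc(O)c3cc(OC)ccc3n2)c1` gives 28.1 ug/mL in this assay and holds the only number shown so far. The change leading to compound 3 `COc1cccc(-c2nc(O)c3cc(OC)c(OC)cc3n2)c1` is methoxy in place of hydrogen on an aromatic carbon and consists of methoxy in place of hydrogen on an aromatic carbon. For the measured compounds named here, no measured pair isolates this change, so no step beyond the scatter is expected in this assay for it. The estimated step of a 1.1-fold lower number from compound 2 to compound 3 (0.05 log units; within the scatter) is expected to stay small. For compound 3 the estimate is 25 ug/mL with an expected range from 12 ug/mL to 50 ug/mL on this read-out.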

Compound 3, concentration for half-maximal effect: > 20 ug/mL
Compound 3 ended at the assay's limit (the forecaster's own chance of this, stated with the estimate: 35%); the middle value lies beyond the limit too.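

No step can be read from compound 2 to compound 3 or from compound 1 to compound 3, because compound 3 and compound 1 both end at a limit: the limit of > 20 ug/mL in this assay, at which 2 of the 3 values shown sit.

The compounds shown leave open what size of effect methoxy in place of hydrogen, or of fluoro, on an aromatic carbon has.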